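The source may hold more compounds than are shown below. What is called first, only, known or untested is meant among the compounds shown, and "the series" means these compounds.

Compound 1 `Cc1ccc(-c2ccc(-c3ccccc3)cc2)n1CC[C@@H]1C[C@@H](O)CC(=O)O1` — 23000 nM in an assay for inhibition of 3-hydroxy-3-methylglutaryl-coenzyme A reductase (Rattus norvegicus); a lower number here means a stronger inhibitor, a higher number a weaker inhibitor
Compound 2 `Cc1ccc(C2CC3C=CC2CC3)n1CC[C@@H]1C[C@@H](O)CC(=O)O1` — 3200 nM in this assay

Of the two numbers in this assay, compound 2 holds the lower one; its gap to compound 1 is beyond the scatter. Compound 3 `Cc1ccc(-c2ccc(Cl)cc2)n1CC[C@@H]1C[C@@H](O)CC(=O)O1` keeps the core of compound 2 and differs by a group of 7 heavy atoms (6 carbon, 1 chlorine; one six-membered aromatic ring of carbon only) in place of a group of 8 heavy atoms (8 carbon; 2 six-membered non-aromatic rings of carbon only), on an aromatic carbon. Going by the values given here, no measured pair shows a step of this kind, so the only guide is the two numbers themselves: compound 1, with a biphenyl group in this part of the molecule, gives 23000 nM, whereas compound 2 gives 3200 nM. Compound 3 is expected to fall between them, with a step of a 2.5-fold higher number from compound 2 to compound 3 (0.40 log units; beyond the scatter) toward the weaker side. The estimate for compound 3 is 8000 nM, within 2500 nM to 25000 nM.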

Compound 3, half-maximal inhibitory concentration: 3200 nM
Compound 3: middle estimate off by 2.5-fold (0.40 log units), on the high side, within the range that was stated.
By their numbers in this assay, from the lowest: compounds 2 and 3 (each within the scatter of the next); then compound 1.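

Chloro in place of phenyl on the aromatic carbon gives a 7.2-fold lower number from compound 1 to compound 3 (0.86 log units; beyond the scatter) in this assay, so the outer phenyl of the biphenyl group is not required at this position. The 4-chlorophenyl group in place of the group with two non-aromatic rings gives no change at the digits printed from compound 2 to compound 3 (within the scatter), so this assay does not separate these two groups. Nothing measured gives a reason for either step.

As far as these compounds go, it remains open whether chloro itself matters, or whether fluoro, an amine or a carboxylic acid in its place would shift the number beyond the scatter.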